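The compounds below may be only part of what the source reports. "The series", "measured", "known", "first", "only" and "open" are said of these compounds alone.

Measured compounds:
- compound 2, `Fc1ccc(Nc2ccnc(NCCCNc3ccnc4cc(Cl)ccc34)n2)cc1`, 13700 nM
- compound 1, `Clc1ccc2c(NCCCNc3nccc(Nc4ccccc4)n3)ccnc2c1`, 12800 nM

Compound 2 was tested in an ADME assay on Vero cells (Chlorocebus sabaeus) for cytotoxicity, read by neutral red uptake, with a stated time of 72 h (a higher number here means a weaker inhibitor, a lower number a stronger inhibitor), and gave 13700 nM. Where compound 2 carries fluoro, compound 1 carries hydrogen, and in the same assay compound 1 gave 12800 nM. The step of a 1.1-fold higher number from compound 1 to compound 2 (0.03 log units; within the scatter) shows that the two numbers lie within the scatter of each other, so no order between compound 1 and compound 2 can be claimed on this evidence.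

Compound 3, `Clc1ccc(Nc2ccnc(NCCCNc3ccnc4cc(Cl)ccc34)n2)cc1`, is the next member of the series. It differs from compound 2 in one place: chloro in place of fluoro on an aromatic carbon. Among the measured compounds shown here, the one measured step that bears on this position is a 1.1-fold higher number from compound 1 to compound 2 (0.03 log units; within the scatter), which exchanged hydrogen for fluoro at the same aromatic carbon and moved the number by an amount within the scatter. For the measured compounds named here, no measured pair shows what a chloro at this place does. On that basis the step from compound 2 to compound 3 is expected to be small, no larger than the scatter, namely a 1.0-fold higher number from compound 2 to compound 3 (0.01 log units; within the scatter). Compound 3 is therefore estimated at 14000 nM in this assay, with a range from 7000 nM to 28000 nM.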

Compound 3, half-maximal inhibitory concentration: 13400 nM
Compound 3: middle estimate off by 1.0-fold (0.02 log units), on the high side; low and high end bracket the measured number.
By their numbers in this assay, from the lowest: compounds 1, 3 and 2 (each within the scatter of the next).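

In this assay a chloro at this place, on an aromatic carbon para to a large group, now has a reading of its own: the exchange of fluoro for chloro gives a 1.0-fold lower number from compound 2 to compound 3 (0.01 log units; within the scatter) and the exchange of hydrogen for chloro gives a 1.0-fold higher number from compound 1 to compound 3 (0.02 log units; within the scatter) so that both steps stay within the scatter. The earlier pair covered only fluoro against hydrogen, whereas compounds 1, 2 and 3 together show that hydrogen, fluoro and chloro at this position cannot be put in any order on these numbers, and that this single-atom exchange on the 4-fluorophenyl group leaves no readable mark in this measurement. Nothing available offers an explanation for this flat result.

The compounds shown leave open whether a group of another kind at the same aromatic carbon, such as methoxy, trifluoromethyl, an amine or a carboxylic acid, would move the number beyond the scatter. They also leave open whether a substituent at another carbon of that ring, or a longer chain joining the two halves of the molecule, would do so.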